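Three limits and a benzofuran swap

The source may report more compounds than this note shows. Statements on the series, on what has been measured and on what is new or still open speak of the compounds shown alone.

Measured in a functional assay on CCRF-CEM cells (Homo sapiens), read by MTT assay, with a stated time of 72 h; a lower number here means a stronger inhibitor, a higher number a weaker inhibitor:
- Compound 1 `Nc1nc(N)c2c(-c3cc4ccccc4o3)cn([C@@H]3O[C@H](CO)[C@@H](O)[C@H]3O)c2n1`, a limit only: > 20000 nM
- Compound 2 `Cc1nc(N)c2c(-c3cccs3)cn([C@@H]3O[C@H](CO)[C@@H](O)[C@H]3O)c2n1`, a limit only: > 20000 nM
- Compound 3 `Cc1nc(N)c2c(-c3ccccc3)cn([C@@H]3O[C@H](CO)[C@@H](O)[C@H]3O)c2n1`, a limit only: > 20000 nM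

Compound 3 has no numerical value, and its result is a limit. The same holds for the other two compounds: the limit of > 20000 nM in this assay, at which 3 of the 3 values shown sit. The step to compound 4 `Cc1nc(N)c2c(-c3cc4ccccc4o3)cn([C@@H]3O[C@H](CO)[C@@H](O)[C@H]3O)c2n1` is 1-benzofuran-2-yl in place of phenyl on an aromatic carbon, with 1-benzofuran-2-yl in place of phenyl on an aromatic carbon. Among the measured compounds shown here, the one measured step, a step that the two limits leave unreadable from compound 2 to compound 3, gives no size to carry over. Compound 1 also bears 1-benzofuran-2-yl, and its result is the limit > 20000 nM. No step beyond the scatter is therefore expected in this assay, and no direction is expected: the estimated step is a number no higher from compound 3 to compound 4 (the limit leaves the size open). Compound 4 is expected at 20000 nM, within an estimated range of 9000 nM to 40000 nM.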

Compound 4, half-maximal inhibitory concentration: > 20000 nM
Compound 4 ended at the assay's limit; the forecaster's own chance of this, stated with the estimate: 85%; the middle value lies on the limit itself.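

Compound 4 gives > 20000 nM, a limit and not a number, so its steps from compound 1, compound 2 and compound 3 cannot be read. The four compounds leave open whether any of these group changes alters potency at all.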